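Hydroxy for chloro on the aryl arm of a shared core

The source may report more compounds than this note shows. Statements on the series, on what has been measured and on what is new or still open speak of the compounds shown alone.

The series rests on one shared core. Compound 1 `N#Cc1c(-c2ccccc2)nc(SCC(=O)Nn2c(COc3ccc(Cl)cc3Cl)nc3ccccc3c2=O)[nH]c1=O` carries a plain phenyl ring on it, and in a functional assay on the whole organism (strain albino) for inhibition, with Rattus norvegicus as the target, read by paw edema, with stated times of 1 h and 2 h, at a dose of 100 mg/kg by the oral route (on this read-out lower numbers stand for less inhibition and higher numbers for more inhibition at the one dose given (going by the name of the read-out)), compound 1 gives 86%. Compound 2 `N#Cc1c(-c2ccc(Cl)cc2)nc(SCC(=O)Nn2c(COc3ccc(Cl)cc3Cl)nc3ccccc3c2=O)[nH]c1=O` carries a chloro on that ring, and in this assay compound 2 gives 64.9%. Going by the values given here, the only measured step, a number 21.1 percentage points lower from compound 1 to compound 2 (beyond the scatter), places compound 2 lowest of the two measured compounds.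

Among the compounds with values here, compound 3 `N#Cc1c(-c2ccc(O)cc2)nc(SCC(=O)Nn2c(COc3ccc(Cl)cc3Cl)nc3ccccc3c2=O)[nH]c1=O` is the next step from compound 2, and its one change is hydroxy in place of chloro on an aromatic carbon; taken one bond further out, it reads 4-chlorophenyl to 4-hydroxyphenyl. Within the data shown here, no measured pair carries this exact change. Among the measured compounds shown here, the only step that bears on it, a number 21.1 percentage points lower from compound 1 to compound 2 (beyond the scatter), shows that putting a chloro on the plain phenyl ring of compound 1 cost a modest amount, beyond the scatter. Removing that chloro for a hydroxy is expected to move compound 3 back toward compound 1 but not the whole way, so a rise of about a number 8.1 percentage points higher from compound 2 to compound 3 (within the scatter) in this assay is estimated. In this assay compound 3 is therefore expected to give 73%, within a range of 56% to 88%.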

Compound 3, a percentage reported as inhibition, in the whole organism at one dose (the size of the read-out at that dose, not a potency): 68.4%
Estimate against measurement, compound 3: 4.6 percentage points above; measured number inside the range.
By their numbers in this assay, from the lowest: compounds 2 and 3 (each within the scatter of the next); then compound 1.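

In this assay, replacing chloro with hydroxy at this position amounts to a number 3.5 percentage points higher from compound 2 to compound 3 (within the scatter), so the two groups cannot be told apart here, even though hydroxy brings a hydrogen-bond donor and a hydrogen-bond acceptor that chloro does not. Measured against the plain phenyl ring, hydroxy gives a number 17.6 percentage points lower from compound 1 to compound 3 (beyond the scatter), and chloro gives a number 21.1 percentage points lower from compound 1 to compound 2 (beyond the scatter), so the loss seen earlier is not confined to chloro: both groups placed on this aromatic carbon sit beyond the scatter below compound 1. Nothing given here speaks to the cause of this shared drop.

From the compounds shown here alone, it remains open whether any group at this position can match the unsubstituted ring of compound 1, or whether a methoxy, an amine or a carboxylic acid would fall in the same range as chloro and hydroxy. Going by these compounds, each reading also comes from a single oral dose, so whether these gaps hold at other doses is unknown.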